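Adding a Second Piperidine Arm to Compound 1

The source may hold more compounds than are shown below. What is called first, only, known or untested is meant among the compounds shown, and "the series" means these compounds.

Of the compounds shown here, three of a shared core have been measured in a physicochemical assay for acid dissociation, read by spectrophotometry. Compound 1 `Cn1cc(O)c(=O)cc1CN1CCCCC1` gives 6.72, the lowest of the three numbers. Compound 2 `CCc1c(O)c(=O)ccn1CCN(C)C` gives 7.16, which lies beyond the usual scatter above compound 1 and is the nearest of the other two. Compound 3 `CC(O)c1c(O)c(=O)ccn1CCN1CCCCC1` gives 7.35, also beyond the scatter above compound 1 and the furthest from it. No pair among these three differs in only one place, so no single step between measured compounds can be read off.

Compound 4 `O=c1cc(CN2CCCCC2)n(CCN2CCCCC2)cc1O` has not yet been measured in this assay. It differs from compound 1 by (piperidin-1-yl)methyl in place of hydrogen on a saturated chain carbon bound to an aromatic nitrogen. Because compound 2 gives 7.16 and compound 3 gives 7.35, both higher than compound 1, a modest rise is expected rather than a fall. The expected step is a number 0.28 log units higher from compound 1 to compound 4 (within the scatter), small and possibly no larger than the scatter. For compound 4 the estimate is 7, within a range from 6.5 to 7.5.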

Compound 4, acid dissociation constant: 7.6
Compound 4: middle estimate off by 0.60 log units, on the low side; measured number outside the range, above it.
By their numbers in this assay, from the lowest: compound 1; then compounds 2, 3 and 4 (each within the scatter of the next, the first and the last beyond it).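

In this assay, placing (piperidin-1-yl)methyl in place of hydrogen on a saturated chain carbon bound to an aromatic nitrogen gives a number 0.88 log units higher from compound 1 to compound 4 (beyond the scatter). This is the first step among these compounds that rests on a single change, so it shows that a change at this place on the chain can move the read-out by more than the usual scatter. No measurement at hand bears on the reason for this rise.

Going by these compounds, it remains open whether a morpholine ring, a carboxylic acid or a longer chain at this same place would move the number as far, not as far, or the other way. A single step also cannot tell whether (piperidin-1-yl)methyl would give a similar step on a compound with different groups elsewhere on the shared core.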